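From butoxy to ethoxy on the shared core

A few compounds are considered here, and "the series" means these few. Any claim that something is new, unique, unknown or untested is made for them only; others in the source may bear on it.

In a functional assay on MCF7 cells (Homo sapiens) for antiproliferative activity, read by sulforhodamine B assay, with a stated time of 3 days (a higher number here means that more compound is needed for the effect, a lower number that less compound is needed), compound 1 (`CCCC1=C(OCC(C)C)C(CCC)(CCC)C(=O)/C(=C(O)\C=C\c2ccccc2)C1=O`) gives 4.4 uM and compound 2 (`CCCCOC1=C(CCC)C(=O)/C(=C(O)/C=C/c2ccccc2)C(=O)C1(CCC)CCC`) gives 5.3 uM. Among the compounds with values here, these are the only two measured values, and they lie within the scatter of each other, so compound 2 stands level with compound 1.

Compound 3 (`CCCC1=C(OCC)C(CCC)(CCC)C(=O)/C(=C(O)\C=C\c2ccccc2)C1=O`) follows from compound 2 by hydrogen in place of ethyl on a saturated chain carbon, two bonds along the chain from an oxygen on an unsaturated carbon, which reads as butoxy to ethoxy. Within the data shown here, one measured step bears on this chain: a 1.2-fold higher number from compound 1 to compound 2 (0.08 log units; within the scatter), with propyl in place of isopropyl on a saturated chain carbon bound to an oxygen on an unsaturated carbon. Among the measured compounds shown here, that step leaves the value within the scatter, but no measured step shortens the chain, so the evidence is thin.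

No change beyond the scatter is expected in this assay, and the estimate is a 1.1-fold higher number from compound 2 to compound 3 (0.05 log units; within the scatter). Compound 3 is expected at 6 uM, within an estimated range of 2.5 uM to 14 uM.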

Compound 3, concentration for half-maximal effect: 2.6 uM
Compound 3: middle estimate off by 2.3-fold (0.36 log units), on the high side; the range from low to high includes it.
By their numbers in this assay, from the lowest: compounds 3, 1 and 2 (each within the scatter of the next, the first and the last beyond it).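

In this assay, within the data shown here, the chain on the oxygen does respond to change: butoxy to ethoxy gives a 2.0-fold lower number from compound 2 to compound 3 (0.31 log units; beyond the scatter), the first step to pass the scatter, though only modestly. The other step at this place, a 1.7-fold lower number from compound 1 to compound 3 (0.23 log units; within the scatter), stays within the scatter, so compound 1, with its isopropyl end, cannot be told apart from compound 3 and stands against any simple rule that shortening the chain lowers the number. Nothing measured on these compounds offers an explanation for the shift.

Still open, going by these compounds, is whether a methoxy group or a longer chain such as hexyloxy would follow the butoxy to ethoxy step. On these data alone, it is also open how an amine or a carboxylic acid at the end of the chain would read in this assay.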